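From 3-chlorophenyl to 4-methylphenyl on a shared core

The source may report more compounds than this note shows. Statements on the series, on what has been measured and on what is new or still open speak of the compounds shown alone.

Among the measured compounds shown here, in a functional assay on NCI-H460 cells (Homo sapiens) for cytotoxicity, read by MTT assay, with a stated time of 72 h (on this read-out higher numbers stand for weaker inhibition and lower numbers for stronger inhibition), compound 1 `CC1CCN(Cc2ccc3nc(NC(=O)N/N=C/c4cn(Cc5cccc(Cl)c5)c5ccccc45)sc3c2)CC1` gives 280 nM and compound 2 `CCN(CC)Cc1ccc2nc(NC(=O)N/N=C/c3cn(Cc4cccc(Cl)c4)c4ccccc34)sc2c1` gives 220 nM, the only two numbers available. Compound 3 `Cc1ccc(Cn2cc(/C=N/NC(=O)Nc3nc4ccc(CN5CCC(C)CC5)cc4s3)c3ccccc32)cc1` carries 4-methylphenyl in place of 3-chlorophenyl on a saturated chain carbon bound to an aromatic nitrogen. For the measured compounds named here, the one measured step, a 1.3-fold lower number from compound 1 to compound 2 (0.10 log units; within the scatter), lies elsewhere, with diethylamino in place of 4-methylpiperidin-1-yl on a saturated chain carbon bound to an aromatic carbon. Going by the values given here, no measured step covers the new change, and no shift beyond the scatter is expected in this assay. The expected step is a 1.1-fold higher number from compound 1 to compound 3 (0.03 log units; within the scatter). For compound 3 the estimated value is 300 nM, with a range of 110 nM to 800 nM.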

Compound 3, half-maximal inhibitory concentration: 410 nM
Beside the measured number, compound 3's estimate is 1.4-fold (0.14 log units) below it, and the stated range covers the measured number.
By their numbers in this assay, from the lowest: compounds 2, 1 and 3 (each within the scatter of the next).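

Replacing 3-chlorophenyl with 4-methylphenyl gives a 1.5-fold higher number from compound 1 to compound 3 (0.17 log units; within the scatter) in this assay, so this position, on a saturated chain carbon bound to an aromatic nitrogen, tolerates this swap with no shift beyond the scatter. Among the compounds shown here, the earlier pair varied only the amine on the other side of the shared core, so this is the first reading at this position. Nothing measured here explains the result.

The chlorine leaves and the methyl enters at a different ring position in one step, so their separate contributions cannot be told apart. Going by these compounds, it also remains open how this position would respond to a plain benzyl group or to a benzyl group carrying a carboxylic acid or an amine.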